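Series notes: phenol capping, compound 2 to compound 3

The compounds below may be only part of what the source reports. "The series", "measured", "known", "first", "only" and "open" are said of these compounds alone.

Among the compounds with values here, compound 2 `O=C(CCCCCc1ccc(O)cc1)N1CCOC1=O` gives 61 nM in an assay on HEK293 cells for inhibition of N-acylethanolamine-hydrolyzing acid amidase (Rattus norvegicus), read by LC-MS, with a stated time of 30 min (on this read-out lower numbers stand for stronger inhibition and higher numbers for weaker inhibition), the lowest of the two numbers measured so far. Within the data shown here, its nearest neighbour is compound 1 `O=C(CCCCCc1ccc(Br)cc1)N1CCOC1=O`, which in this assay gives 8510 nM; the only measured step, a 140-fold lower number from compound 1 to compound 2 (2.14 log units; beyond the scatter), is hydroxy in place of bromo on an aromatic carbon. Compound 3 `COc1ccc(CCCCCC(=O)N2CCOC2=O)cc1` differs from compound 2 by methyl in place of hydrogen on an oxygen on an aromatic ring. Among the measured compounds shown here, no measured step covers this change directly. For the measured compounds named here, the one step that bears on it, a 140-fold lower number from compound 1 to compound 2 (2.14 log units; beyond the scatter), shows that the number reacts strongly to what is attached at that aromatic carbon, so a change on the hydroxy oxygen is not expected to be neutral. Because of a 140-fold lower number from compound 1 to compound 2 (2.14 log units; beyond the scatter), partly undoing the hydroxy-for-bromo change by capping the oxygen with methyl is expected to raise the number again, though by less than the full gap, since the oxygen itself remains. Compound 3 is therefore expected to give 1500 nM, within 300 nM to 8000 nM, in this assay, a step of a 25-fold higher number from compound 2 to compound 3 (1.39 log units; beyond the scatter) that is expected to lie beyond the scatter.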

Compound 3, half-maximal inhibitory concentration: > 20000 nM
Compound 3 ended at the assay's limit; the forecaster's own chance of this, stated with the estimate: 5%; at least 13-fold (1.12 log units) between middle value and limit.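

In this assay compound 3 is held at a limit of the assay and has no exact number: the limit of > 20000 nM in this assay, at which 1 of the 3 values shown sits.

Until now the series showed only that hydroxy in place of bromo on the aromatic carbon lowers the number; it could not separate the oxygen from the hydrogen it carries. Methyl in place of that hydrogen gives an at least 320-fold higher number from compound 2 to compound 3 (2.51 log units; beyond the scatter), so in this pair an oxygen at that aromatic carbon is not enough on its own, and the low number depends on the uncapped hydroxy. Methoxy in place of bromo gives an at least 2.3-fold higher number from compound 1 to compound 3 (0.37 log units; beyond the scatter), which places the capped compound on the weak side of the bromo compound rather than partway towards the phenol, although the true size of both steps stays unknown at the limit.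

Still open, from the compounds shown here alone, is whether the loss follows any group on this oxygen or is particular to methyl, as an acetyl group there would begin to show. Going by these compounds, it is equally open whether an amine or a carboxylic acid on the same aromatic carbon could stand in for the hydroxy, or whether a longer chain would change how much this position matters.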